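The source may hold more compounds than are shown below. What is called first, only, known or untested is meant among the compounds shown, and "the series" means these compounds.

Measured compounds:
- compound 1, `O=S(=O)(Nc1ccc(Cl)c(Cl)c1)c1ccc(-c2cnc(C3CC3)o2)cc1`: 62100 nM
- compound 2, `O=S(=O)(Nc1ccc(Cl)cc1Cl)c1ccc(-c2cnc(C3CC3)o2)cc1`: 74500 nM
- compound 3, `O=S(=O)(Nc1ccc(Br)c(Cl)c1)c1ccc(-c2cnc(C3CC3)o2)cc1`: 70300 nM

The three compounds were measured in a functional assay on cells (leukaemia cell line, Homo sapiens) for inhibition, read by sulforhodamine B assay, with a stated time of 48 h; on this read-out higher numbers stand for weaker inhibition of growth and lower numbers for stronger inhibition of growth. All three share the same core and differ only in the substituted phenyl ring on the sulfonamide nitrogen. Compound 2 gives the highest of the three numbers, but its nearest neighbour is compound 3, a 1.1-fold lower number from compound 2 to compound 3 (0.03 log units; within the scatter), and its furthest is compound 1, a 1.2-fold higher number from compound 1 to compound 2 (0.08 log units; within the scatter), so the three values cannot be told apart.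

The next compound, compound 4, `O=S(=O)(Nc1cc(Cl)ccc1Cl)c1ccc(-c2cnc(C3CC3)o2)cc1`, has not yet been measured. It differs from compound 2 in one place: 2,5-dichlorophenyl in place of 2,4-dichlorophenyl on a sulfonamide nitrogen. Within the data shown here, two measured steps bear on a change of this kind. The move from compound 1 to compound 2, also a rearrangement of two chlorines on the phenyl ring, gave a 1.2-fold higher number from compound 1 to compound 2 (0.08 log units; within the scatter). The exchange of a chlorine pattern in the step from compound 2 to compound 3 gave a 1.1-fold lower number from compound 2 to compound 3 (0.03 log units; within the scatter). Neither step rises above the scatter, so no step beyond the scatter is expected in this assay for compound 4 either.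

Compound 4 is therefore estimated to give 70000 nM, in the range 35000 nM to 140000 nM, which is expected to amount to a 1.1-fold lower number from compound 2 to compound 4 (0.03 log units; within the scatter).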

Compound 4, concentration for total growth inhibition: > 100000 nM
Compound 4: a limit, no number; the forecaster's own chance of this, stated with the estimate: 15%; middle value at least 1.4-fold (0.15 log units) from the limit.
By their numbers in this assay, from the lowest: compounds 1, 3 and 2 (each within the scatter of the next). At a limit, above all of these: compound 4.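

In this assay compound 4 gives > 100000 nM, which is a limit of the assay and not a number: the limit of > 100000 nM in this assay, at which 1 of the 4 values shown sits. Placing 2,5-dichlorophenyl in place of 2,4-dichlorophenyl on the sulfonamide nitrogen gives an at least 1.3-fold higher number from compound 2 to compound 4 (0.12 log units; that floor lies within the scatter), while the comparisons with the other two rings give an at least 1.4-fold higher number from compound 3 to compound 4 (0.15 log units; that floor lies within the scatter) and an at least 1.6-fold higher number from compound 1 to compound 4 (0.20 log units; that floor lies within the scatter). Among these compounds, these floors do not by themselves separate compound 4 from the others, but compounds 1, 2 and 3 all gave numbers within the scatter of one another, and the 2,5-dichlorophenyl ring is the first pattern on this nitrogen to give a limit, so the earlier impression that the halogen pattern here makes no difference no longer holds with certainty.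

The compounds shown leave open how far compound 4 really lies from the other three, and so whether this rearrangement of the two chlorines produces a step beyond the scatter at all. They also leave open whether a methoxy group or a carboxylic acid on the same phenyl ring, in place of a chlorine, would shift the number in this assay beyond the scatter.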